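This account rests on a few compounds, and the source may have more. Where it says the series, first, only, none or still open, it means among the compounds named here.

Two compounds share a fused two-ring core that carries a chloro group and an aromatic arm bearing a chloromethyl group. Compound 1 `ClCc1ccc(Cn2cnc3c(Cl)ncnc32)cc1` and compound 2 `ClCc1cccc(Cn2cnc3ncnc(Cl)c32)c1` differ only in where that chloromethyl group sits on the arm. In a functional assay on Hs-578T cells (Homo sapiens) for cytotoxicity, read by sulforhodamine B assay, with a stated time of 48 h (a higher number here means a weaker inhibitor of growth, a lower number a stronger inhibitor of growth), compound 1 gives 38900 nM, and compound 2 gives 42700 nM. Compound 1 has the lower of the two numbers, but its gap to compound 2 lies within the scatter, so the two cannot be told apart. Compound 3 `ClCc1ccc(Cn2cnc3c(Cl)nc(Cl)nc32)cc1` has not yet been measured; it differs from compound 1 by chloro in place of hydrogen on an aromatic carbon, the new chloro entering between two ring nitrogen atoms. Going by the values given here, no measured pair shows what such a change does here. With nothing to go on beyond the two numbers, the expected step from compound 1 to compound 3 is small, a 1.3-fold lower number from compound 1 to compound 3 (0.11 log units; within the scatter), with no confident direction. Compound 3 is therefore estimated at 30000 nM, in a range from 10000 nM to 90000 nM.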

Compound 3, concentration for total growth inhibition: 5750 nM
Compound 3: the middle estimate sits 5.2-fold (0.72 log units) above what was measured; the measured number lies below the stated range.
By their numbers in this assay, from the lowest: compound 3; then compounds 1 and 2 (each within the scatter of the next).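

The position between two ring nitrogen atoms clearly matters in this assay: chloro in place of hydrogen there gives a 6.8-fold lower number from compound 1 to compound 3 (0.83 log units; beyond the scatter). Compound 1 and compound 2, which differ only in where the chloromethyl group sits on the arm, could not be told apart, so this is the first change among the compounds shown to move the number beyond the scatter. Nothing available explains this step.

On these data alone, it remains open whether chloro is special at this position, or whether an amine, a methoxy group or a methyl group there would give a similar number. As far as these compounds go, it is also open whether the same change would have a similar effect with the chloromethyl group placed as in compound 2.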